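This account rests on a few compounds, and the source may have more. Where it says the series, first, only, none or still open, it means among the compounds named here.

For the measured compounds named here, compound 1 `O=C1/C(=C/c2ccccc2)CCc2ccc(O)cc21` is one of two compounds measured in a functional assay on RAW264.7 cells (Mus musculus) for inhibition (a lower number here means a stronger inhibitor, a higher number a weaker inhibitor), where compound 1 gives 710 nM. Going by the values given here, its only neighbour is compound 2 `O=C1/C(=C/c2ccc(Cl)cc2)CCc2ccc(O)cc21`, which in this assay gives 1100 nM; the step of a 1.5-fold higher number from compound 1 to compound 2 (0.19 log units; within the scatter) places the two within the scatter, so compound 1 stands with compound 2 rather than apart from it. Compound 3 `O=C1/C(=C/c2cccnc2)CCc2ccc(O)cc21` differs from compound 1 by pyridin-3-yl in place of phenyl on a double-bonded chain carbon bound to a double-bonded ring carbon. Among the compounds with values here, no measured step changes the aromatic ring itself; the only step known, from compound 1 to compound 2, swaps one substituent on that ring and stays within the scatter. On that basis no step beyond the scatter is expected for compound 3, and the step of a 1.3-fold higher number from compound 1 to compound 3 (0.10 log units; within the scatter) is estimated to be small in either direction. Compound 3 is therefore expected to give about 900 nM, within a range of 350 nM to 2500 nM.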

Compound 3, half-maximal inhibitory concentration: 3040 nM
Compound 3: middle estimate off by 3.4-fold (0.53 log units), on the low side, outside the stated range (above it).
By their numbers in this assay, from the lowest: compounds 1 and 2 (each within the scatter of the next); then compound 3.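

In this assay, the aromatic ring on the double-bonded chain carbon bound to a double-bonded ring carbon proves sensitive to a change within the ring itself: pyridin-3-yl in place of phenyl gives a 4.3-fold higher number from compound 1 to compound 3 (0.63 log units; beyond the scatter), whereas chloro in place of hydrogen on that ring gave only a 1.5-fold higher number from compound 1 to compound 2 (0.19 log units; within the scatter). The swap leaves the count of heavy atoms unchanged and brings in one nitrogen and one hydrogen-bond acceptor, so a change of one ring atom is enough for a step beyond the scatter at this place. No measurement here accounts for this step.

Going by these compounds, what pyridin-2-yl or pyridin-4-yl would give at this place remains open. Also open, on these data alone, is whether a methoxy group or an amine on the phenyl ring would leave the number within the scatter of compound 1.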